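The source may report more compounds than this note shows. Statements on the series, on what has been measured and on what is new or still open speak of the compounds shown alone.

Three measured compounds share one core. Compound 1 `COc1ccc(-c2nn3cc(-c4cccc(N)c4)nc3s2)cc1OC` carries an amine, while compound 2 `C=C(Br)C(=O)Nc1cccc(-c2cn3nc(-c4ccc(OCC)cc4)sc3n2)c1` and compound 3 `C=C(Br)C(=O)Nc1cccc(-c2cn3nc(-c4ccc(C)cc4)sc3n2)c1` carry a bromoacrylamide and differ from each other in one group. In a functional assay on HeLa cells (Homo sapiens) for inhibition, read by cell counting, with a stated time of 4 days (a lower number here means a stronger inhibitor, a higher number a weaker inhibitor), compound 1 gives 26000 nM, compound 2 gives 1100 nM and compound 3 gives 2000 nM. Compound 3 thus stands second highest of the three numbers: its nearest neighbour is compound 2, and the step of a 1.8-fold higher number from compound 2 to compound 3 (0.26 log units; within the scatter) lies within the scatter, while compound 1 lies furthest away, its number separated from that of compound 3 by more than the scatter. Compound 4 `C=C(Br)C(=O)Nc1cccc(-c2cn3nc(CCc4ccccc4)sc3n2)c1` differs from compound 3 in one place: phenethyl in place of 4-methylphenyl on an aromatic carbon. Within the data shown here, no measured step concerns this kind of change; the only step in hand, a 1.8-fold higher number from compound 2 to compound 3 (0.26 log units; within the scatter), concerns a methyl in place of ethoxy and says nothing about phenethyl in place of 4-methylphenyl. Without a guide, a modest weakening is estimated, with a wide range around it. Compound 4 is therefore expected to give 4000 nM, between 1300 nM and 12000 nM, which amounts to an expected step of a 2.0-fold higher number from compound 3 to compound 4 (0.30 log units; within the scatter).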

Compound 4, half-maximal inhibitory concentration: 3300 nM
Beside the measured number, compound 4's estimate is 1.2-fold (0.08 log units) above it, within the range that was stated.
By their numbers in this assay, from the lowest: compounds 2, 3 and 4 (each within the scatter of the next, the first and the last beyond it); then compound 1.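

In this assay, the earlier step only exchanged a small group, whereas this change replaces the whole 4-methylphenyl on this aromatic carbon with phenethyl, a group of 8 heavy atoms rather than 7 that keeps a six-membered aromatic ring of carbon only, and the result is a 1.7-fold higher number from compound 3 to compound 4 (0.22 log units; within the scatter). Among these compounds, this position therefore tolerates a larger alteration than the earlier compounds could show, at least for this pair, though the comparison with the 4-ethoxyphenyl group gives a 3.0-fold higher number from compound 2 to compound 4 (0.48 log units; beyond the scatter), a modest step that does clear the scatter. No measurement in hand explains either step.

Still open, from the compounds shown here alone, is how this position responds to a shorter benzyl group, a longer phenylpropyl chain, or a phenethyl group bearing an amine or a carboxylic acid on its ring. Also open, going by these compounds, is what the bromoacrylamide itself contributes, since compound 1 differs from the others in more than one place, and only a pair differing solely in that group, such as the amine set against the bromoacrylamide on an identical core, could separate its part.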